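Swapping the amide aryl group on a shared thiazole-carboxamide core

This account rests on a few compounds, and the source may have more. Where it says the series, first, only, none or still open, it means among the compounds named here.

Measured compounds:
- compound 1, `CN1CCN(c2ccc(Nc3nc(-c4cccc(NC(=O)c5ccc(C(C)(C)C)cc5)c4)sc3C(N)=O)cc2)CC1` — "not determined" (no result reported)
- compound 2, `CN1CCN(c2ccc(Nc3nc(-c4cccc(NC(=O)c5ccccc5F)c4)sc3C(N)=O)cc2)CC1` — 3270 nM
- compound 3, `CN1CCN(c2ccc(Nc3nc(-c4cccc(NC(=O)c5ccc(F)c(Cl)c5)c4)sc3C(N)=O)cc2)CC1` — 6230 nM

Compound 1 carries a tert-butylphenyl on the amide carbonyl, and in a functional assay on Raji cells (Homo sapiens) for antiproliferative activity, read by CCK-8 assay, with a stated time of 72 h (on this read-out lower numbers stand for stronger inhibition and higher numbers for weaker inhibition), compound 1 stands as "not determined" (no result reported). Compound 2 gives 3270 nM in this assay, and compound 3 gives 6230 nM. Going by the values given here, the only step between measured compounds, a 1.9-fold higher number from compound 2 to compound 3 (0.28 log units; within the scatter), falls within the scatter, so compound 2 and compound 3 cannot be told apart on these numbers.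

Compound 4, `CN1CCN(c2ccc(Nc3nc(-c4cccc(NC(=O)c5ccc(C(F)(F)F)cn5)c4)sc3C(N)=O)cc2)CC1`, differs from compound 3 by 5-(trifluoromethyl)pyridin-2-yl in place of 3-chloro-4-fluorophenyl on a carbonyl carbon. Among the compounds with values here, the one measured step that bears on this change, a 1.9-fold higher number from compound 2 to compound 3 (0.28 log units; within the scatter), also exchanged the aryl group on that same carbonyl carbon and produced no change beyond the scatter. With a single relevant step and no other information, compound 4 is therefore expected to sit close to compound 3, and the step of a 1.2-fold lower number from compound 3 to compound 4 (0.10 log units; within the scatter) is estimated to stay within the scatter. Compound 4 is expected to give about 5000 nM in this assay, with a likely range from 2000 nM to 15000 nM.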

Compound 4, half-maximal inhibitory concentration: 24500 nM
For compound 4 the middle estimate is 4.9-fold (0.69 log units) below the measured one, and the stated range ends below it.
By their numbers in this assay, from the lowest: compounds 2 and 3 (each within the scatter of the next); then compound 4.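

The earlier exchange on this carbonyl carbon stayed within the scatter, but this one shows that the aryl group placed here can matter: in this assay the 5-(trifluoromethyl)pyridin-2-yl group gives a 3.9-fold higher number from compound 3 to compound 4 (0.59 log units; beyond the scatter) and a 7.5-fold higher number from compound 2 to compound 4 (0.87 log units; beyond the scatter) and both steps lie beyond the scatter. Among the three compounds with numbers, compound 4 is therefore the weakest inhibitor, while compound 2 and compound 3 stay together. Nothing shown gives a cause for this loss.

This change replaces the ring and its substituent together, leaving open whether the ring nitrogen or the trifluoromethyl group accounts for the step; a trifluoromethylphenyl group or an unsubstituted pyridyl group on the same carbonyl carbon would separate the two. Steps involving compound 1 cannot be read, so the tert-butylphenyl group also remains open.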